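The compounds below may be only part of what the source reports. "The series", "measured", "known", "first", "only" and "open" are said of these compounds alone.

Measured so far:
compound 1, `CS/C(=N\C(=O)c1cc2ccccc2s1)NC(=O)c1cc2ccccc2s1`, 43400 nM
compound 2, `CS/C(=N\C(=O)c1ccco1)NC(=O)c1ccco1`, a limit only
compound 3, `O=C(/N=C(/NC(=O)c1ccco1)[Se]Cc1ccccc1)c1ccco1`, 58000 nM

In a functional assay on MCF7 cells (Homo sapiens) for cytotoxicity, read by MTT assay, with a stated time of 72 h (a higher number here means a weaker inhibitor of growth, a lower number a stronger inhibitor of growth), compound 1 gives 43400 nM. Compound 2 gives > 100000 nM, which is a limit and not a number. Compound 3 gives 58000 nM.

From compound 2 to compound 3 the change is a group of 8 heavy atoms (7 carbon, 1 selenium; one six-membered aromatic ring of carbon only) in place of a group of 2 heavy atoms (1 carbon, 1 sulfur; no ring), on a carbon with a double bond to nitrogen. The step is an at least 1.7-fold lower number from compound 2 to compound 3 (0.23 log units; that floor lies within the scatter); it is only a floor because of the limit of > 100000 nM in this assay, at which 1 of the 3 values shown sits. How the core of compound 1 differs from the core of compound 2 is not broken down here; the values of compound 1 and compound 3 sit within the scatter of one another.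

Compound 4, `O=C(/N=C(/NC(=O)c1cc2ccccc2s1)[Se]Cc1ccccc1)c1cc2ccccc2s1`, is not yet measured. It differs from compound 1 by a group of 8 heavy atoms (7 carbon, 1 selenium; one six-membered aromatic ring of carbon only) in place of a group of 2 heavy atoms (1 carbon, 1 sulfur; no ring), on a carbon with a double bond to nitrogen, the same change as from compound 2 to compound 3. Beside that earlier step, the step expected here is a 1.2-fold lower number from compound 1 to compound 4 (0.09 log units; within the scatter), a small one. This rests on the two measured carriers of the leaving group and of the entering group on this core, which sit close to each other: compound 1 gives 43400 nM and compound 3 gives 58000 nM. For compound 4 the expected value is 35000 nM, with a range from 15000 nM to 90000 nM.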

Compound 4, concentration for total growth inhibition: 62900 nM
Compound 4: the middle estimate sits 1.8-fold (0.25 log units) below what was measured, and the stated range covers the measured number.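

In this assay, putting the selenium-bearing group with its six-membered aromatic ring in place of methylsulfanyl on the core of compound 1 gives a 1.4-fold higher number from compound 1 to compound 4 (0.16 log units; within the scatter), so on this core the change has no effect that can be told from the scatter. Compound 2 has a limit and not a number, so the step on its core is only a floor: the limit of > 100000 nM in this assay, at which 1 of the 4 values shown sits. Set side by side, the two steps show neither that the change carries over unaltered from one core to the other nor that it behaves differently on each: the same change on two cores in this assay, an at least 1.7-fold lower number (0.23 log units; that floor lies within the scatter) from compound 2 to compound 3 and a 1.4-fold higher number (0.16 log units; within the scatter) from compound 1 to compound 4; the limit leaves it open whether they differ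

The change alters the sulfur-to-selenium atom and the attached group together, so the compounds shown leave open what each part contributes on its own; a benzylsulfanyl group or a methyl group on selenium would separate the two. Also open, as far as these compounds go, is how this series responds on that same carbon to an amine or a longer alkyl chain.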